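One Methyl Less on the Sulfonamide Nitrogen

The source may report more compounds than this note shows. Statements on the series, on what has been measured and on what is new or still open speak of the compounds shown alone.

Compound 1, `Cc1ccc(C(F)(F)F)cc1COc1cc(NC(=O)c2ccc3ccccc3c2)ccc1N(C)S(C)(=O)=O`: 18400 nM
Compound 2, `COc1ccc(OC)c(COc2cc(NC(=O)c3ccc4ccccc4c3)ccc2N(C)S(C)(=O)=O)c1`: 16.6 nM

Both compounds were tested in a functional assay on SK-BR-3 cells (Homo sapiens) for antiproliferative activity, read by MTT assay, with a stated time of 48 h; a higher number here means a weaker inhibitor, a lower number a stronger inhibitor. Within the data shown here, compound 2 has the lower of the two numbers, and the only comparison available is to compound 1, which lies a 1100-fold lower number from compound 1 to compound 2 (3.04 log units; beyond the scatter) away. That single step comes from exchanging the whole aryl group on a saturated chain carbon bound to an oxygen on an aromatic ring, and it is very large.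

Compound 3, `COc1ccc(OC)c(COc2cc(NC(=O)c3ccc4ccccc4c3)ccc2NS(C)(=O)=O)c1`, keeps everything from compound 2 except for one detail: hydrogen in place of methyl on a sulfonamide nitrogen. Among the measured compounds shown here, no measured step touches the sulfonamide nitrogen, so the large step between compound 1 and compound 2 says nothing about this change. For the measured compounds named here, with no step of its own kind to lean on, the most reasonable expectation is a modest move, at most a little beyond the scatter and more likely inside it. Compound 3 is therefore estimated at about 30 nM, within a range of 6 nM to 200 nM. The expected step of a 1.8-fold higher number from compound 2 to compound 3 (0.26 log units; within the scatter) is small and is offered as an estimate only.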

Compound 3, half-maximal inhibitory concentration: 13.3 nM
For compound 3 the middle estimate is 2.3-fold (0.35 log units) above the measured one; the range from low to high includes it.
By their numbers in this assay, from the lowest: compounds 3 and 2 (each within the scatter of the next); then compound 1.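

Replacing the methyl on the sulfonamide nitrogen with hydrogen leaves the two compounds indistinguishable in this assay, with a step of a 1.2-fold lower number from compound 2 to compound 3 (0.10 log units; within the scatter). The earlier compounds shown here all carried that methyl, so they could show only what exchanging the aryl group does, namely a 1100-fold lower number from compound 1 to compound 2 (3.04 log units; beyond the scatter); now it is clear that, with the rest of compound 2 held fixed, this nitrogen can carry either methyl or hydrogen with no difference beyond the scatter. No measurement shown here offers an explanation for this result.

On these data alone, the nitrogen change is seen with the 2,5-dimethoxyphenyl group only, so it remains open whether the same would hold with the 2-methyl-5-(trifluoromethyl)phenyl group of compound 1, whose number is so much higher. The compounds shown also leave open how far this tolerance extends, for instance to an ethyl group or a longer chain on the same nitrogen, or to an acetyl group in place of the sulfonyl part.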